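This account rests on a few compounds, and the source may have more. Where it says the series, first, only, none or still open, it means among the compounds named here.

Measured compounds and their results in a functional assay on CHO-K1 cells for agonist activity at Glucose-dependent insulinotropic receptor (Homo sapiens), read by HTRF and cAMP accumulation, with a stated time of 30 min; a lower number here means a smaller maximal response, a higher number a larger maximal response:

compound 1 `CC(C)(C)OC(=O)N1CCC(CCCOc2ccc3c(c2)CCS3(=O)=O)CC1`, with 84%
compound 2 `CC(C)(C)OC(=O)N1CCC(CCCNc2ccc3c(c2)C(=O)CO3)CC1`, with 95%
compound 3 `COc1cnc(N2CCC(CCCNc3ccc4c(c3)OCC4=O)CC2)nc1`, with 101%

Compound 3 gives the highest of the three numbers in this assay. Its nearest neighbour is compound 2, whose result sits within the usual scatter of compound 3, so the two cannot be told apart. The furthest is compound 1, whose result lies beyond the scatter, a genuinely smaller maximal response. No pair among these three differs in only one place, so no single structural step can be drawn from the measured set.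

Compound 4 `CC(C)c1nc(N2CCC(CCCNc3ccc4c(c3)OCC4=O)CC2)no1` is the compound still to be tested. Set against compound 3, it carries 5-isopropyl-1,2,4-oxadiazol-3-yl in place of 5-methoxypyrimidin-2-yl on an amine nitrogen in a ring. The rest of the molecule is unchanged: the same core, the same three-carbon chain and the same amine link to the ring.

Since compound 3 already reaches a maximal response close to full in this assay and the exchange swaps one aromatic group of equal size for another, the step from compound 3 to compound 4 is expected to be small, in either direction, and not beyond the scatter: a number 4 percentage points lower from compound 3 to compound 4 (within the scatter). Compound 4 is accordingly estimated to give 97%, with a range from 84% to 110%.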

Compound 4, largest response reached (Emax), in percent of the reference or control that the assay uses: 91%
Compound 4: the middle estimate sits 6 percentage points above what was measured, within the range that was stated.
By their numbers in this assay, from the lowest: compounds 1, 4, 2 and 3 (each within the scatter of the next, the first and the last beyond it).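

In this assay, among these compounds, putting 5-isopropyl-1,2,4-oxadiazol-3-yl in place of 5-methoxypyrimidin-2-yl gives the first change in one place that can be read in this set, a number 10 percentage points lower from compound 3 to compound 4 (within the scatter), so the two compounds cannot be told apart. This shows that, on an amine nitrogen in a ring, a five-membered aromatic ring with 3 hetero atoms can stand in for a six-membered aromatic ring with 2 hetero atoms, both groups having 8 heavy atoms, without a change in maximal response that goes beyond the scatter. No measured evidence here bears on why the two groups behave alike.

The compounds shown leave open whether a phenyl ring, an open-chain amide or a carboxylic acid on the same nitrogen would also keep the response, and whether a longer chain in place of the three-carbon chain would alter it. Among the compounds shown here, they also leave open whether this exchange would give a similar step on the core of compound 1, since that single pair is the only comparison available.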